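The source may hold more compounds than are shown below. What is called first, only, known or untested is meant among the compounds shown, and "the series" means these compounds.

Compound 1 `COc1ccc(-c2cnc(NC(=O)c3ccco3)n2C)cc1` carries a furan-2-yl on the carbonyl carbon of its amide. In a toxicity assay on THP-1 cells (Homo sapiens) for inhibition (a lower number here means that less compound is tolerated, a higher number that more compound is tolerated), compound 1 gives > 100000 nM, which is a limit of the assay and not a number. Compound 2 `Cn1c(-c2ccccc2)cnc1NC(=O)c1ccc(Br)cc1` shares the same kind of core. In this assay compound 2 gives > 100000 nM, again a limit rather than a number. Among the compounds with values here, what is known so far is therefore (the limit of > 100000 nM in this assay, at which 2 of the 2 values shown sit), and no measured step joins any two compounds. Compound 3 `COc1ccc(-c2cnc(NC(=O)c3cccc(OC)c3)n2C)cc1` remains to be measured; it differs from compound 1 by 3-methoxyphenyl in place of furan-2-yl on a carbonyl carbon. Since both known values rest at the limit, no step beyond the scatter is expected in this assay in either direction, and compound 3 is most likely to return a limit as well. Compound 3 is estimated at 150000 nM, with a range from 60000 nM to 400000 nM. The step this estimate implies, a step that the limit leaves unreadable from compound 1 to compound 3, is expected to stay within the scatter.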

Compound 3, half-maximal cytotoxic concentration: > 100000 nM
Compound 3: only a limit was reported (the forecaster's own chance of this, stated with the estimate: 80%); the middle value does not contradict the limit.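

Within the data shown here, compound 1 and compound 3 both rest at a limit in this assay, so no step between them can be read: (the limit of > 100000 nM in this assay, at which 3 of the 3 values shown sit). The compounds shown leave open which change on the carbonyl carbon, if any, would give a number in this assay rather than a limit.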